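The compounds below may be only part of what the source reports. "The series", "measured", "known", "first", "only" and "open" are said of these compounds alone.

Compounds measured so far:
- compound 1, `COc1cc(NC(=O)Nc2cc(Nc3ccc(C(C)(C)C)cc3)ncn2)cc(OC)c1`: 47.7%
- compound 2, `COc1ccc(F)cc1Nc1cc(NC(=O)Nc2c(Cl)cccc2Cl)ncn1`: 31.3%

Of the compounds shown here, two have been tested in a functional assay on NCI-H226 cells (Homo sapiens) for inhibition, read by MTT assay, with a stated time of 48 h, tested at 10 uM; on this read-out lower numbers stand for less inhibition and higher numbers for more inhibition at the one concentration tested (going by the name of the read-out). Compound 1 stands highest of the two numbers; its nearest neighbour, compound 2, lies lower by a gap beyond the usual scatter. Compound 3, `COc1cc(NC(=O)Nc2cc(Nc3ccc(F)c(Cl)c3)ncn2)cc(OC)c1`, has not yet been measured. It is built from compound 1 by one change: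

3-chloro-4-fluorophenyl in place of 4-(tert-butyl)phenyl on a nitrogen on an aromatic ring

Within the data shown here, no pair of measured compounds differs in only this one place, so there is no measured step to lean on; what can be said rests on compound 1 alone, which gives 47.7% in this assay. A modest step is expected, most likely downwards, though a change within the scatter would not surprise. The expected step of a number 7.7 percentage points lower from compound 1 to compound 3 (within the scatter) reflects this. For compound 3 the estimate in this assay is 40%, with a range from 20% to 60%.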

Compound 3, a percentage reported as inhibition, at one concentration (the size of the read-out at that concentration, not a potency): 36.7%
For compound 3 the middle estimate is 3.3 percentage points above the measured one, and the stated range covers the measured number.
By their numbers in this assay, from the lowest: compounds 2 and 3 (each within the scatter of the next); then compound 1.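

In this assay, putting 3-chloro-4-fluorophenyl in place of 4-(tert-butyl)phenyl on a nitrogen on an aromatic ring gives a number 11 percentage points lower from compound 1 to compound 3 (beyond the scatter). The read-out therefore responds to what sits at this position, yet the swap does not abolish inhibition, as compound 3 still gives 36.7%. Both groups hold one six-membered aromatic ring of carbon only, so the ring stays and its substituents change, but no measurement at hand shows which feature of the swap accounts for the step.

This single pair cannot separate the loss of the tert-butyl group from the arrival of the chlorine and fluorine. It also leaves open how this position would respond to an amine, a carboxylic acid or a longer alkyl chain on the phenyl ring.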